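This account rests on a few compounds, and the source may have more. Where it says the series, first, only, none or still open, it means among the compounds named here.

Compound 1, `CC(=O)c1cc(-c2ccccc2)cc2cc(-c3ccccc3)[nH]c12`: in a functional assay on HeLa cells (Homo sapiens) for cytotoxicity, read by MTT assay, with a stated time of 2 days (a higher number here means that more compound is tolerated, a lower number that less compound is tolerated), compound 1 gives > 100000 nM, which is a limit of the assay.
Compound 2, `CC(=O)c1cc(-c2ccc(F)cc2)cc2cc(-c3ccccc3)[nH]c12`: in this assay compound 2 gives 38000 nM.
Compound 3, `COc1ccc(-c2cc3cc(-c4ccc(F)cc4)cc(C(C)=O)c3[nH]2)cc1`: in this assay compound 3 gives 42800 nM.

Within the data shown here, compound 2 holds the lowest of the two numbers measured so far; the nearest is compound 3, and the two lie within the scatter of each other. Compound 1 sits at the limit of > 100000 nM in this assay, at which 1 of the 3 values shown sits.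

Compound 4, `CC(=O)c1cc(/C=C/c2ccccc2)cc2cc(-c3ccccc3)[nH]c12`, differs from compound 2 by 2-phenylethenyl in place of 4-fluorophenyl on an aromatic carbon. Among the measured compounds shown here, two measured steps bear on this. The step of an at least 2.6-fold lower number from compound 1 to compound 2 (0.42 log units; beyond the scatter) is the only one beyond the scatter, and it went toward less tolerated compound when fluorine came in. The step of a 1.1-fold higher number from compound 2 to compound 3 (0.05 log units; within the scatter) stayed within the scatter. Compound 4 takes away the fluorine together with the ring that carried it and brings in a 2-phenylethenyl group, a change that neither measured step covers directly. Since compound 2 lost tolerance relative to compound 1 by an at least 2.6-fold lower number from compound 1 to compound 2 (0.42 log units; beyond the scatter), the removal of that fluorine in compound 4 is expected to move the number back upward, though the new group leaves the size uncertain. The expected step is a 1.6-fold higher number from compound 2 to compound 4 (0.20 log units; within the scatter). For compound 4 the estimate in this assay is 60000 nM, in a range from 22000 nM to 160000 nM.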

Compound 4, concentration lethal to 50% of the cells: 30800 nM
The estimate for compound 4 lay 1.9-fold (0.29 log units) above the measured number; low and high end bracket the measured number.
By their numbers in this assay, from the lowest: compounds 4, 2 and 3 (each within the scatter of the next). At a limit, above all of these: compound 1.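

In this assay, putting 2-phenylethenyl in place of 4-fluorophenyl on this aromatic carbon, meta to the acetyl group, gives a 1.2-fold lower number from compound 2 to compound 4 (0.09 log units; within the scatter), so the two groups cannot be told apart here, and a fluorine is not required for a number in this range. Set against the plain phenyl group at the same carbon, 2-phenylethenyl gives an at least 3.2-fold lower number from compound 1 to compound 4 (0.51 log units; beyond the scatter), which makes it the second change at this position to go beyond the scatter, and it does so with a group that carries no fluorine at all. Compound 1 stands at a limit of the assay, so this step, like the one to compound 2, fixes only a minimum size: the limit of > 100000 nM in this assay, at which 1 of the 4 values shown sits.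

The compounds shown leave open whether the double bond of the 2-phenylethenyl group matters, which 2-phenylethyl at the same carbon would test. They also leave open whether a group of another kind at this carbon, such as an amine or a carboxylic acid, would keep the number in this range or return it to the limit.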